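A Dimethylphenyl Variant in a Weakly Active Series

The source may hold more compounds than are shown below. What is called first, only, known or untested is meant among the compounds shown, and "the series" means these compounds.

In a functional assay on MCF7 cells (Homo sapiens) for antiproliferative activity, read by MTT assay, with a stated time of 48 h (a lower number here means a stronger inhibitor, a higher number a weaker inhibitor), compound 1 `N#CC1=C(N)Oc2c(c3nc4ccccc4nc3c3ccccc23)C12C(=O)N(Cc1cnnn1-c1ccc(Cl)cc1)c1ccccc12` reaches only the assay limit, > 50000 nM. Compound 2 `N#CC1=C(N)Oc2c(c3nc4ccccc4nc3c3ccccc23)C12C(=O)N(Cc1cnnn1-c1ccc(Br)cc1)c1ccccc12` gives 36600 nM in this assay. Compound 3 `COc1ccccc1-n1nncc1CN1C(=O)C2(C(C#N)=C(N)Oc3c2c2nc4ccccc4nc2c2ccccc32)c2ccccc21` likewise reaches only the limit, > 50000 nM. It thus stands at the limit of > 50000 nM in this assay, at which 2 of the 3 values shown sit, with no number of its own.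

Compound 4 `Cc1cc(C)cc(-n2nncc2CN2C(=O)C3(C(C#N)=C(N)Oc4c3c3nc5ccccc5nc3c3ccccc43)c3ccccc32)c1` differs from compound 3 by 3,5-dimethylphenyl in place of 2-methoxyphenyl on an aromatic nitrogen. The steps that touch compound 3 are a step that the two limits leave unreadable from compound 1 to compound 3 and an at least 1.3-fold higher number from compound 2 to compound 3 (0.13 log units; that floor lies within the scatter), neither of which shows a change beyond the scatter, so no shift beyond the scatter is expected from exchanging one phenyl substituent for another. Compound 4 is therefore expected to give 50000 nM in this assay, within 20000 nM to 150000 nM, most probably again as a limit. The expected step is a number no higher from compound 3 to compound 4 (the limit leaves the size open).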

Compound 4, half-maximal inhibitory concentration: > 50000 nM
Compound 4: only a limit was reported (the forecaster's own chance of this, stated with the estimate: 65%); the middle value lies on the limit itself.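

In this assay, going by these compounds alone, a phenyl group carrying two methyl groups and made of carbon only, in place of one carrying methoxy, still gives no value on this aromatic nitrogen, so the limit now holds for a third substituent: the limit of > 50000 nM in this assay, at which 3 of the 4 values shown sit. The one readable step is an at least 1.3-fold higher number from compound 2 to compound 4 (0.13 log units; that floor lies within the scatter). The other two new steps cannot be read, as both ends of each are limits.

As far as these compounds go, whether a 4-aminophenyl or 4-carboxyphenyl group, or a butyl chain in place of the phenyl ring, on this nitrogen would give a readable value remains open.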